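Notes on compound 3 after the aryl exchange

The compounds below may be only part of what the source reports. "The series", "measured", "known", "first", "only" and "open" are said of these compounds alone.

Measured so far:
compound 1 `O=[N+]([O-])c1ccc(C2=NN(C(=S)Nc3ccccc3)C(c3ccc4c(c3)OCCO4)C2)cc1` — in a functional assay on WM 266-4 cells (Homo sapiens) for antiproliferative activity, read by MTT assay, with a stated time of 48 h (on this read-out lower numbers stand for stronger inhibition of growth and higher numbers for weaker inhibition of growth), compound 1 gives 105000 nM
compound 2 `S=C(Nc1ccccc1)N1N=C(c2cccc(Cl)c2)CC1c1ccc2c(c1)OCCO2` — for compound 2 the value > 200000 nM is a limit of the assay, not a number

Among the measured compounds shown here, compound 1 holds the only numeric value shown in this assay, and it sits in the range of weak inhibition of growth. The step of an at least 1.9-fold higher number from compound 1 to compound 2 (0.27 log units; that floor lies within the scatter) is only a floor, since the limit of > 200000 nM in this assay, at which 1 of the 2 values shown sits, describes where one of the two values ends up.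

Compound 3 `Cc1ccc(C2=NN(C(=S)Nc3ccccc3)C(c3ccc4c(c3)OCCO4)C2)cc1C` differs from compound 1 by 3,4-dimethylphenyl in place of 4-nitrophenyl on a carbon with a double bond to nitrogen. For the measured compounds named here, the one measured step at the same position, the exchange for 3-chlorophenyl from compound 1 to compound 2, yields a floor within the scatter rather than a size, and no measured pair shows what a dimethylated aryl does here. The expected step is a 1.4-fold higher number from compound 1 to compound 3 (0.15 log units; within the scatter), with a fair chance that only a limit is returned. Compound 3 is estimated at 150000 nM, within 60000 nM to 300000 nM.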

Compound 3, concentration for 50% growth inhibition: 70500 nM
Compound 3: middle estimate off by 2.1-fold (0.33 log units), on the high side; low and high end bracket the measured number.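

In this assay, 3,4-dimethylphenyl in place of 4-nitrophenyl gives a 1.5-fold lower number from compound 1 to compound 3 (0.17 log units; within the scatter), so these two aryl groups cannot be told apart on this carbon. Among the compounds shown here, the exchange of 3-chlorophenyl for 3,4-dimethylphenyl gives an at least 2.8-fold lower number from compound 2 to compound 3 (0.45 log units; beyond the scatter), the first step at this position that clears the scatter, which shows that the number does respond to the aryl group here. Compound 2 carries a limit of the assay and not a number, so that step is only a floor: the limit of > 200000 nM in this assay, at which 1 of the 3 values shown sits.

From the compounds shown here alone, it remains open which part of the change from 3-chlorophenyl to 3,4-dimethylphenyl carries the step. Also open, going by these compounds, is how a phenyl bearing an amine or a carboxylic acid, or a longer chain in place of the aryl group, would read at this position.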